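Swapping the aryl amide for a cyclopentyl amide

The source may report more compounds than this note shows. Statements on the series, on what has been measured and on what is new or still open speak of the compounds shown alone.

Measured compounds in a physicochemical assay for solubility, read by HPLC; on this read-out higher numbers stand for higher solubility and lower numbers for lower solubility:
Compound 1, `O=c1nc(N2CCN(CC3CCCCC3)CC2)sc2c([N+](=O)[O-])cc(C(F)(F)F)cc12`: 9.07 ug/mL
Compound 2, `O=C(c1ccc(F)cc1)N1CCN(c2nc(=O)c3cc(C(F)(F)F)cc([N+](=O)[O-])c3s2)CC1`: 1.69 ug/mL
Compound 3, `O=C(c1ccccc1Cl)N1CCN(c2nc(=O)c3cc(C(F)(F)F)cc([N+](=O)[O-])c3s2)CC1`: 8.18 ug/mL

On these three numbers compound 3 holds the second highest place. Its nearest neighbour is compound 1, and the gap between them is within the scatter, so the two cannot be ordered (a 1.1-fold lower number from compound 1 to compound 3 (0.04 log units; within the scatter)). Its furthest neighbour is compound 2, which lies beyond the scatter (a 4.8-fold higher number from compound 2 to compound 3 (0.68 log units; beyond the scatter)).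

Compound 4, `O=C(C1CCCC1)N1CCN(c2nc(=O)c3cc(C(F)(F)F)cc([N+](=O)[O-])c3s2)CC1`, is the next compound, and it differs from compound 3 in one place: cyclopentyl in place of 2-chlorophenyl on a carbonyl carbon.

Going by the values given here, only one measured step touches the group on the carbonyl carbon, the exchange of one aryl ring for another, and it was modest (a 4.8-fold higher number from compound 2 to compound 3 (0.68 log units; beyond the scatter)). The other two steps replace the whole group on the amine nitrogen in the ring: a 5.4-fold lower number from compound 1 to compound 2 (0.73 log units; beyond the scatter) and a 1.1-fold lower number from compound 1 to compound 3 (0.04 log units; within the scatter). Among the compounds with values here, no measured step exchanges an aromatic ring for a non-aromatic ring on the carbonyl carbon, so the direction rests on little. A step no larger than the modest ones seen, and possibly within the scatter, is expected: a 1.4-fold lower number from compound 3 to compound 4 (0.13 log units; within the scatter). Compound 4 is therefore estimated at 6 ug/mL, with a range from 2 ug/mL to 20 ug/mL.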

Compound 4, solubility: 5.34 ug/mL
For compound 4 the middle estimate is 1.1-fold (0.05 log units) above the measured one; measured number inside the range.
By their numbers in this assay, from the lowest: compound 2; then compounds 4, 3 and 1 (each within the scatter of the next).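

In this assay, putting a non-aromatic ring on the carbonyl carbon gives no readable change from 2-chlorophenyl (a 1.5-fold lower number from compound 3 to compound 4 (0.19 log units; within the scatter)), so at this position the exchange of that aromatic ring for cyclopentyl does not separate the two compounds. The same cyclopentyl does separate from 4-fluorophenyl (a 3.2-fold higher number from compound 2 to compound 4 (0.50 log units; beyond the scatter)), which makes compound 2 the only one of the four set apart from the rest, while compound 3 goes against any rule that an aromatic ring on this carbonyl carbon lowers the number. On the amine nitrogen in the ring, cyclopentylcarbonyl also cannot be told apart from cyclohexylmethyl (a 1.7-fold lower number from compound 1 to compound 4 (0.23 log units; within the scatter)), so the presence of a carbonyl there does not by itself mark a difference among these compounds.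

The data shown offer no explanation for why compound 2 stands apart from the others. Also open, going by these compounds, is whether an amine, a carboxylic acid or a longer chain on the carbonyl carbon would bring a step beyond the scatter from cyclopentyl, and whether any such group would lift the number clear of compound 1.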